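A few compounds are considered here, and "the series" means these few. Any claim that something is new, unique, unknown or untested is made for them only; others in the source may bear on it.

Of the compounds shown here, three have so far been tested in a functional assay on A549 cells (Homo sapiens) for cytotoxicity, read by MTT assay, with a stated time of 72 h; a lower number here means a stronger inhibitor, a higher number a weaker inhibitor. Compound 1 `c1ccc2[nH]c(-n3cccn3)cc2c1` gives > 100000 nM, which is a limit of the assay and not a number. Compound 2 `O=C1NC(=O)c2c1c1[nH]ncc1c1[nH]c3ccccc3c21` gives > 100000 nM, which is also a limit. Going by the values given here, compound 3 `COc1ccc2[nH]c3c(c4c(c5ccnn53)C(=O)NC4=O)c2c1`, with a methoxy group on its core, gives 8000 nM, the only actual number among the three, so there is no measured value to rank it against.

Compound 4 `Cc1ccc2[nH]c3c(c4c(c5ccnn53)C(=O)NC4=O)c2c1` keeps the core of compound 3 and has methyl in place of methoxy on an aromatic carbon, in a six-membered aromatic ring of carbon only: methyl in place of methoxy on an aromatic carbon. It is a small edit, and the group stays at the same place on the core.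

Among the compounds with values here, no two measured compounds differ in one place only, so the data give no direct measure of what this swap does. In this assay the expectation is therefore a small step toward weaker inhibition, one that stays within the usual scatter of repeated measurements. The starting point for that expectation is compound 3 at 8000 nM. The expected change is a 1.4-fold higher number from compound 3 to compound 4 (0.14 log units; within the scatter). For compound 4 the estimated value is 11000 nM, with an expected range of 3000 nM to 40000 nM.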

Compound 4, half-maximal inhibitory concentration: 8000 nM
Estimate against measurement, compound 4: 1.4-fold (0.14 log units) above; measured number inside the range.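

In this assay, going by these compounds alone, methyl in place of methoxy on an aromatic carbon gives no change at the digits printed from compound 3 to compound 4 (within the scatter), and this is the only step so far that can be read at a single place. At this position, meta to a fused ring and para to a fused ring, the methoxy group with its oxygen and its hydrogen-bond acceptor can therefore give way to methyl with no change beyond the scatter, while the rest of the core stays the same. Compound 1 and compound 2 could not show this, since each gives only a limit of the assay and neither differs in one place from another compound shown: the limit of > 100000 nM in this assay, at which 2 of the 4 values shown sit.

As far as these compounds go, two groups with the same result say little about the position as a whole, so it remains open how far this place accepts other groups. An amine, a carboxylic acid or a longer chain such as ethoxy at the same carbon could move the number in either direction, and the pair of compound 3 and compound 4 gives no way of telling which.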